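A Methyl on the Linker of a Bile Acid Receptor Agonist

This account rests on a few compounds, and the source may have more. Where it says the series, first, only, none or still open, it means among the compounds named here.

compound 1 `CN(Cc1ccc(C(=O)O)cc1)c1ccc(OCc2c(-c3c(Cl)cccc3Cl)noc2C2CC2)nc1C(F)(F)F` 81%
compound 2 `O=C(O)c1ccccc1OCc1ccc(OCc2c(-c3c(Cl)cccc3Cl)noc2C2CC2)nc1C(F)(F)F` 63%
compound 3 `O=C(O)c1ccc(OCc2ccc(OCc3c(-c4c(Cl)cccc4Cl)noc3C3CC3)nc2C(F)(F)F)cc1` 59%

In a functional assay on HEK293 cells for agonist activity at Bile acid receptor (Homo sapiens) (on this read-out higher numbers stand for larger maximal responses and lower numbers for smaller maximal responses), compound 1 gives 81%, compound 2 gives 63% and compound 3 gives 59%, the lowest of the three numbers, though close to compound 2: a number 4 percentage points lower from compound 2 to compound 3 (within the scatter). The distance to compound 1 is larger: a number 22 percentage points lower from compound 1 to compound 3 (beyond the scatter).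

Compound 4 `CC(Oc1ccc(C(=O)O)cc1)c1ccc(OCc2c(-c3c(Cl)cccc3Cl)noc2C2CC2)nc1C(F)(F)F` differs from compound 3 in one place: methyl in place of hydrogen on a saturated chain carbon bound to an aromatic carbon and an oxygen on an aromatic ring. Within the data shown here, none of the measured steps touches this spot; they exchange the whole group joining the carboxyphenyl to the shared core, as in a number 18 percentage points lower from compound 1 to compound 2 (beyond the scatter) and a number 22 percentage points lower from compound 1 to compound 3 (beyond the scatter). A methyl added on the linker has no measured parallel here, so in this assay the expected change is a number 1 percentage points lower from compound 3 to compound 4 (within the scatter), nothing beyond the scatter. Compound 4 is therefore estimated at 58%, between 45% and 72%.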

Compound 4, largest response reached (reported as efficacy), in percent of the reference or control that the assay uses: 70%
Compound 4: the middle estimate sits 12 percentage points below what was measured; the measured number falls inside the stated range.
By their numbers in this assay, from the lowest: compounds 3, 2 and 4 (each within the scatter of the next, the first and the last beyond it); then compound 1.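

A single methyl on this saturated chain carbon is enough to shift the response in this assay, with a number 11 percentage points higher from compound 3 to compound 4 (beyond the scatter), so this position is not silent even though the rest of the structure stays the same. The 1-(4-carboxyphenoxy)ethyl group cannot be told apart from the (2-carboxyphenoxy)methyl group, with a number 7 percentage points higher from compound 2 to compound 4 (within the scatter), but it does not match the (4-carboxybenzyl)(methyl)amino group, with a number 11 percentage points lower from compound 1 to compound 4 (beyond the scatter). Nothing measured here explains the gain from the methyl.

Going by these compounds, whether an ethyl group or a hydroxyl group on this same carbon would act like the methyl remains open. So does the effect of a methyl on the matching carbon of the (2-carboxyphenoxy)methyl group.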